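Chain-end variation on a hydroxyphenyl isoflavone series

The compounds below may be only part of what the source reports. "The series", "measured", "known", "first", "only" and "open" are said of these compounds alone.

Measured compounds:
- compound 1, `O=C(O)CCCCOc1ccc2c(=O)c(-c3ccc(O)cc3)coc2c1`, an assay (Cricetulus griseus) for inhibition of aldehyde dehydrogenase, mitochondrial (Homo sapiens); on this read-out lower numbers stand for stronger inhibition and higher numbers for weaker inhibition: 100 nM
- compound 2, `O=c1c(-c2ccc(O)cc2)coc2cc(OCCCCCCCCCO)ccc12`, this assay: 700 nM
- compound 3, `O=c1c(-c2ccc(O)cc2)coc2cc(OCCCCCCO)ccc12`, this assay: 120 nM

The three measured compounds share one core and differ only in the chain on the aromatic oxygen. Compound 2 carries the longest chain and gives the highest number of the three. The change carboxy in place of 5-hydroxypentyl on a saturated chain carbon, four bonds along the chain from an oxygen on an aromatic ring brought a 7.0-fold lower number from compound 2 to compound 1 (0.85 log units; beyond the scatter). The core of compound 3 differs from that of compound 2 by hydroxy in place of 3-hydroxypropyl on a saturated chain carbon, six bonds along the chain from an oxygen on an aromatic ring, giving a 5.8-fold lower number from compound 2 to compound 3 (0.77 log units; beyond the scatter). Compound 1 and compound 3, side by side, differ by a 1.2-fold higher number from compound 1 to compound 3 (0.08 log units; within the scatter), so these two are not separated.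

Compound 4, `O=C(O)COc1ccc2c(=O)c(-c3ccc(O)cc3)coc2c1`, is not yet measured. It differs from compound 3 by carboxy in place of 5-hydroxypentyl on a saturated chain carbon bound to an oxygen on an aromatic ring. This is the same kind of change as that from compound 2 to compound 1, but the place is not the same: in compound 4 the carboxy sits on a saturated chain carbon bound to an oxygen on an aromatic ring, whereas in compound 1 it sits four bonds along the chain from that oxygen. The whole chain is therefore much shorter in compound 4 than in any measured compound.

Because the step of a 7.0-fold lower number from compound 2 to compound 1 (0.85 log units; beyond the scatter) came with a long chain, and compound 1 and compound 3 are within scatter of each other, a smaller step is expected here, estimated at a 2.1-fold higher number from compound 3 to compound 4 (0.32 log units; beyond the scatter). Compound 4 is therefore expected to give about 250 nM, estimated between 60 nM and 1000 nM.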

Compound 4, half-maximal inhibitory concentration: 1200 nM
Compound 4: middle estimate off by 4.8-fold (0.68 log units), on the low side, outside the stated range (above it).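

In this assay, carboxy in place of 5-hydroxypentyl does not carry from one core to the other with a shared direction or size: the same change on two cores in this assay, a 7.0-fold lower number (0.85 log units; beyond the scatter) from compound 2 to compound 1 and a 10-fold higher number (1.00 log units; beyond the scatter) from compound 3 to compound 4, 70-fold (1.85 log units) apart, beyond the scatter of two such steps. The shortest carboxy chain also stands apart from two of the other chains, with a 10-fold higher number from compound 3 to compound 4 (1.00 log units; beyond the scatter) and a 12-fold higher number from compound 1 to compound 4 (1.08 log units; beyond the scatter), whereas a 1.7-fold higher number from compound 2 to compound 4 (0.23 log units; within the scatter) does not separate that pair. For the compounds shown here, this does not show a general rule for moving the change between cores: there is only one pair per core, and the place differs, with carboxy four bonds along the chain from an oxygen on an aromatic ring in one pair and on a saturated chain carbon bound to an oxygen on an aromatic ring in the other, so place and overall chain length cannot be told apart.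

The compounds shown leave open how the number runs across carboxy-ended chains of intermediate length, and whether a short hydroxy-ended chain would track with compound 4 or with the longer chains. Also open, as far as these compounds go, is how other chain ends, such as an amine or a primary amide, would compare on these chains.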